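The compounds below may be only part of what the source reports. "The series", "measured", "known", "first", "only" and "open" are said of these compounds alone.

Compound 1 `O=C(Nc1ccc([N+](=O)[O-])cc1OCc1ccccc1)c1ccccc1` and compound 2 `O=C(Nc1ccc([N+](=O)[O-])cc1OCc1ccccc1)C1CCCCC1` share one core; compound 3 `CN(c1ccc(NC(=O)c2ccccc2)cc1OCc1ccccc1)S(C)(=O)=O` and compound 4 `CN(c1ccc(NC(=O)C2CCCCC2)cc1OCc1ccccc1)S(C)(=O)=O` share another, and the difference between the two cores is not broken down here. In an assay on SK-BR-3 cells for inhibition of Aromatase (Homo sapiens) (on this read-out higher numbers stand for weaker inhibition and lower numbers for stronger inhibition), compound 1 gives > 25000 nM, a limit of the assay. In this assay compound 2 gives > 25000 nM, likewise a limit. The change between them is cyclohexyl in place of phenyl on a carbonyl carbon, and its step is a step that the two limits leave unreadable from compound 1 to compound 2 because of the limit of > 25000 nM in this assay, at which 2 of the 3 values shown sit. In this assay, for the measured compounds named here, compound 3 gives 1770 nM, the only number among the three. Compound 4 carries the same change, (cyclohexyl in place of phenyl on a carbonyl carbon), on the core of compound 3. An expected step of a 1.4-fold higher number from compound 3 to compound 4 (0.15 log units; within the scatter) rests only on compound 3 at 1770 nM and on the unreadable a step that the two limits leave unreadable from compound 1 to compound 2. Compound 4 is estimated at 2500 nM, expected between 700 nM and 12000 nM.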

Compound 4, half-maximal inhibitory concentration: 250 nM
Beside the measured number, compound 4's estimate is 10-fold (1.00 log units) above it; measured number below the stated range.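

In this assay, cyclohexyl in place of phenyl on a carbonyl carbon gives a 7.1-fold lower number from compound 3 to compound 4 (0.85 log units; beyond the scatter) on the core of compound 3. This single readable pair shows the effect of the change on that core only, and it gives no general rule for the series. Whether the step carries over from one core to the other cannot be read, because compound 1 and compound 2 both stand at a limit of the assay: the limit of > 25000 nM in this assay, at which 2 of the 4 values shown sit.

The compounds shown leave open how cyclopentyl or an open chain such as hexyl on the carbonyl carbon would compare with cyclohexyl on the core of compound 3. As far as these compounds go, it also remains open whether an amine on that ring would keep the number of compound 4.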